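This account rests on a few compounds, and the source may have more. Where it says the series, first, only, none or still open, it means among the compounds named here.

Measured compounds:
Compound 1, `CC(C)CNc1nc(N)nc2c1ncn2/C=C1/CC1(CO)CO`: "not determined" (no result reported)
Compound 2, `CCCCCCCCSc1nc(N)nc2c1ncn2/C=C1/CC1(CO)CO`: > 20000 nM
Compound 3, `CSc1nc(N)nc2c1ncn2/C=C1/CC1(CO)CO`: > 20000 nM

These three compounds share a core and were examined in an ADME assay on MOLT-3 cells (Homo sapiens) for cytotoxicity, with a stated time of 7 days; on this read-out lower numbers stand for higher toxicity in this test and higher numbers for lower toxicity in this test. For compound 1 no result was reported, so nothing can be said of it here. The entry for compound 2 is a limit of this assay, not a number. The entry for compound 3 is likewise a limit and not a number. Compound 3 therefore stands at the edge of what the test can report, and compound 2 sits at the same edge, which is the limit of > 20000 nM in this assay, at which 2 of the 3 values shown sit. Among the compounds with values here, the only step between measured compounds, a step that the two limits leave unreadable from compound 2 to compound 3, cannot be sized because both ends rest on (the limit of > 20000 nM in this assay, at which 2 of the 3 values shown sit).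

Compound 4, `Nc1nc(SC2CCCC2)c2ncn(/C=C3/CC3(CO)CO)c2n1`, is the next compound to be measured. It differs from compound 3 by cyclopentyl in place of methyl on a sulfur. Within the data shown here, no measured step bears on this change in a readable way, since the single step available is unreadable, so there is no ground to expect movement beyond the scatter in either direction. The expectation is that compound 4 also reaches only the limit, with the estimated step that the limit leaves unreadable from compound 3 to compound 4. The estimate for compound 4 is 30000 nM, expected to lie between 12000 nM and 100000 nM.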

Compound 4, half-maximal cytotoxic concentration: > 20000 nM
Compound 4: no number, only a limit; the forecaster's own chance of this, stated with the estimate: 80%; the middle value lies beyond the limit too.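

In this assay compound 4 gives > 20000 nM, which is a limit and not a number. Its steps from compound 2 and from compound 3 cannot be read, as all three compounds rest on the same limit: the limit of > 20000 nM in this assay, at which 3 of the 4 values shown sit.

The compounds shown leave open how much toxicity, if any, compounds 2, 3 and 4 show beyond this limit, and whether they differ from one another.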